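Thiophen-2-yl in place of furan-2-yl on the shared core

The source may report more compounds than this note shows. Statements on the series, on what has been measured and on what is new or still open speak of the compounds shown alone.

Compound 1 `O=C(NC1CCCCC1)c1cnn2c(C(F)F)cc(C3CC3)nc12` has no result in a functional assay on Daoy cells (Homo sapiens) for antiproliferative activity, read by trypan blue exclusion and crystal violet staining, with a stated time of 72 h; on this read-out higher numbers stand for weaker inhibition and lower numbers for stronger inhibition: compound 1 gives "not determined" (no result reported). Compound 2 `Cc1cc(C(F)F)n2ncc(C(=O)NC3CC(C)(C)Oc4ccccc43)c2n1` is reported in this assay without a number, compound 2 giving "not active" (no number reported). Going by the values given here, compound 3 `O=C(NC1CCCc2ccccc21)c1cnn2c(C(F)(F)F)cc(-c3ccco3)nc12` therefore stands as the only entry with a number in this assay, compound 3 giving 5700 nM, with two further entries without one. Compound 4 `O=C(NC1CCCc2ccccc21)c1cnn2c(C(F)(F)F)cc(-c3cccs3)nc12` differs from compound 3 in one place: thiophen-2-yl in place of furan-2-yl on an aromatic carbon. Among the compounds with values here, no step between measured compounds exists to calibrate this exchange, so nothing in the data fixes its size or direction. The exchange is expected to change this assay by little, within the usual scatter, so the expected step is a 1.3-fold lower number from compound 3 to compound 4 (0.10 log units; within the scatter). Compound 4 is estimated at 4500 nM, with a range from 1500 nM to 13000 nM.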

Compound 4, half-maximal inhibitory concentration: 4400 nM
The estimate for compound 4 lay 1.0-fold (0.01 log units) above the measured number; low and high end bracket the measured number.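

In this assay, the aromatic carbon next to the ring nitrogen now has its first readable step: thiophen-2-yl in place of furan-2-yl gives a 1.3-fold lower number from compound 3 to compound 4 (0.11 log units; within the scatter). Sulfur for oxygen in this five-membered aromatic ring therefore leaves the two compounds indistinguishable on this read-out, and neither ring can be ranked above the other. No supporting measurement bears on the reason for this result.

As far as these compounds go, whether this position also accepts a non-aromatic group, such as an amine or a longer alkyl chain, remains open. Also open, from the compounds shown here alone, is whether a carboxylic acid on the five-membered ring would keep a measurable number.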